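Two Fluorines Replace a Methoxy Group

The source may report more compounds than this note shows. Statements on the series, on what has been measured and on what is new or still open speak of the compounds shown alone.

Compound 2 `COc1ccc(C(=O)/C=C/c2cc(-c3cc(OC)c(OC)c(OC)c3)n[nH]2)cc1` gives the lower of the two numbers measured in a functional assay on SW-620 cells (Homo sapiens) for inhibition, read by sulforhodamine B assay, with a stated time of 48 h (a higher number here means a weaker inhibitor of growth, a lower number a stronger inhibitor of growth), at 3470 nM. Compound 1 `COc1cc(-c2cc(/C=C/C(=O)c3ccc(Cl)c(Cl)c3)[nH]n2)cc(OC)c1OC` gives 79600 nM, and the step of a 23-fold lower number from compound 1 to compound 2 (1.36 log units; beyond the scatter) shows how strongly the group on the carbonyl carbon can shift the result. Compound 3 `COc1cc(-c2cc(/C=C/C(=O)c3ccc(F)c(F)c3)[nH]n2)cc(OC)c1OC` carries 3,4-difluorophenyl in place of 4-methoxyphenyl on a carbonyl carbon. For the measured compounds named here, its 3,4-difluorophenyl is closer in kind to the 3,4-dichlorophenyl of compound 1 than to the 4-methoxyphenyl of compound 2, so the one relevant step points back toward compound 1. For compound 3 the expected step is a 7.2-fold higher number from compound 2 to compound 3 (0.86 log units; beyond the scatter). Compound 3 is therefore estimated at 25000 nM, within a range from 8000 nM to 80000 nM.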

Compound 3, concentration for total growth inhibition: > 100000 nM
Compound 3: only a limit was reported (the forecaster's own chance of this, stated with the estimate: 10%); middle value at least 4.0-fold (0.60 log units) away from the limit.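

Compound 3 gives only a limit, not a number: the limit of > 100000 nM in this assay, at which 1 of the 3 values shown sits. Even so, the change on the carbonyl carbon gives an at least 28-fold higher number from compound 2 to compound 3 (1.45 log units; beyond the scatter), so a second halogenated ring, not just the 3,4-dichlorophenyl of compound 1, gives a far higher number than the 4-methoxyphenyl. The comparison between the two halogenated rings gives an at least 1.2-fold higher number from compound 1 to compound 3 (0.09 log units; that floor lies within the scatter), so that floor does not separate them.

Going by these compounds, it remains open whether an amine or a hydroxyl group on this phenyl ring would match compound 2. How far the true value of compound 3 lies past its limit is also unknown.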